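Furan-2-yl to furan-3-yl on the shared core

A few compounds are considered here, and "the series" means these few. Any claim that something is new, unique, unknown or untested is made for them only; others in the source may bear on it.

In a functional assay on MDA-MB-468 cells (Homo sapiens) for inhibition, read by CCK-8 assay and cell counting, with a stated time of 2 days (on this read-out higher numbers stand for weaker inhibition and lower numbers for stronger inhibition), compound 1 (`O=C(/C=C/c1ccco1)c1ccccc1OCC1CO1`) gives 48300 nM and compound 2 (`O=C(/C=C/c1cccs1)c1ccccc1OCC1CO1`) gives 7710 nM. Compound 3 (`O=C(/C=C/c1ccco1)c1ccc(OCC2CO2)cc1`) gives 48900 nM, a value within the scatter of that of compound 1, so these two share the high end of the three numbers, with compound 2 well below them.

Compound 4 (`O=C(/C=C/c1ccoc1)c1ccc(OCC2CO2)cc1`) has not yet been measured. The change from compound 3 is furan-3-yl in place of furan-2-yl on a double-bonded chain carbon bound to a double-bonded chain carbon. The two have the same atoms, joined differently.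

Going by the values given here, only one measured step bears on that place: a 6.3-fold lower number from compound 1 to compound 2 (0.80 log units; beyond the scatter), with thiophen-2-yl in place of furan-2-yl. That step was modest but beyond the scatter. Among the compounds with values here, it replaces the furan with another ring, however, whereas compound 4 keeps the furan, and no furan-3-yl compound has yet been measured. The step therefore serves only as a rough upper guide to size. A small move towards a lower number in this assay is expected, probably not beyond the scatter, and the estimated step is a 1.4-fold lower number from compound 3 to compound 4 (0.15 log units; within the scatter). For compound 4 the expected value is 35000 nM, with an estimated range of 13000 nM to 80000 nM.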

Compound 4, half-maximal inhibitory concentration: 16500 nM
For compound 4 the middle estimate is 2.1-fold (0.33 log units) above the measured one; measured number inside the range.
By their numbers in this assay, from the lowest: compound 2; then compound 4; then compounds 1 and 3 (each within the scatter of the next).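

In (this assay), changing only how the furan is joined moves the number beyond the scatter (a 3.0-fold lower number from compound 3 to compound 4 (0.47 log units; beyond the scatter)), even though furan-2-yl and furan-3-yl have the same atoms and the same counts of heavy atoms and hydrogen-bond acceptors. The earlier step at this place (a 6.3-fold lower number from compound 1 to compound 2 (0.80 log units; beyond the scatter)) exchanged the furan-2-yl for thiophen-2-yl, so it could not show that this position on a double-bonded chain carbon also responds to how the same ring is attached. Nothing at hand accounts for the lower number given by the furan-3-yl compound.

The compounds shown leave open whether furan-3-yl would bring a similar step on the core of compound 1, and how thiophen-2-yl would read on the core of compound 3. On these data alone, it also remains open how an amine or a carboxylic acid carried on the furan-3-yl ring, or a longer chain in its place, would read in this same measurement (this assay).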